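Methoxy in place of chloro: working notes on compound 4

A few compounds are considered here, and "the series" means these few. Any claim that something is new, unique, unknown or untested is made for them only; others in the source may bear on it.

Measured in a functional assay on MCF7 cells (Homo sapiens) for antiproliferative activity, read by MTT assay, with a stated time of 72 h; on this read-out higher numbers stand for weaker inhibition and lower numbers for stronger inhibition:
- compound 1 `COc1ncc(-c2ccc3c(c2)N(C2CCCCC2)C(=O)CO3)cc1NS(=O)(=O)c1ccc(F)cc1` gives 30100 nM
- compound 2 `CC(C)N1C(=O)COc2ccc(-c3cnc(Cl)c(NS(=O)(=O)c4ccc(F)cc4)c3)cc21` gives 26600 nM
- compound 3 `O=C1COc2ccc(-c3cnc(Cl)c(NS(=O)(=O)c4ccc(F)cc4)c3)cc2N1c1ccc(F)cc1` gives 32600 nM

Compound 2 gives 26600 nM and cannot be separated from the other two compounds, since compound 1 and compound 3 both lie within the scatter of it. The set therefore shows no order in this assay.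

Compound 4 `COc1ncc(-c2ccc3c(c2)N(C(C)C)C(=O)CO3)cc1NS(=O)(=O)c1ccc(F)cc1` keeps the isopropyl group of compound 2 and differs from it in one place, with methoxy in place of chloro on an aromatic carbon next to the ring nitrogen.

Within the data shown here, the only measured single-place step is a 1.2-fold higher number from compound 2 to compound 3 (0.09 log units; within the scatter) and it lies within the scatter. That step concerns the amide-type nitrogen, not the place that changes here, so it bears on compound 4 only indirectly. Compound 1 also carries methoxy at this place but has a different group on that nitrogen, and compound 1 gives 30100 nM in this assay, within the scatter of compound 2. Among the measured compounds shown here, no measured step isolates methoxy against chloro. With nothing in the series moving beyond the scatter, no step beyond the scatter is expected, and no direction is favoured. The expected change is small (estimated as a 1.1-fold higher number from compound 2 to compound 4 (0.02 log units; within the scatter) in this assay and so within the scatter). For compound 4 the estimated value is 28000 nM in this assay, with an expected range from 14000 nM to 55000 nM (an estimate, not a measurement).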

Compound 4, half-maximal inhibitory concentration: 17000 nM
Beside the measured number, compound 4's estimate is 1.6-fold (0.22 log units) above it; the range from low to high includes it.
By their numbers in this assay, from the lowest: compounds 4, 2, 1 and 3 (each within the scatter of the next).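

In this assay, among these compounds, the exchange of chloro for methoxy on the aromatic carbon next to the ring nitrogen is now isolated for the first time, with the isopropyl group held constant: a 1.6-fold lower number from compound 2 to compound 4 (0.19 log units; within the scatter). This step lies within the scatter, so the two groups cannot be told apart at this position, and the added oxygen and carbon of methoxy, with its hydrogen-bond acceptor, give no separable shift in this read-out. With methoxy held constant, isopropyl in place of cyclohexyl on the amide-type nitrogen gives a 1.8-fold lower number from compound 1 to compound 4 (0.25 log units; within the scatter), so this nitrogen also shows no separable difference in the methoxy compounds, as a 1.2-fold higher number from compound 2 to compound 3 (0.09 log units; within the scatter) already showed for a different pair of groups in the chloro compounds, and nothing available accounts for either result.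

As far as these compounds go, the position is covered here by chloro and methoxy alone, so it remains open whether an amine, a carboxylic acid or a longer chain such as butoxy would give a step beyond the scatter. From the compounds shown here alone, it also remains open whether a hydrogen or a carboxylic acid-bearing chain on the amide-type nitrogen would separate from isopropyl, cyclohexyl and 4-fluorophenyl.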